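From Benzyl Amide to Pyridinylmethyl Amide: A Lipophilicity Estimate

The compounds below may be only part of what the source reports. "The series", "measured", "known", "first", "only" and "open" are said of these compounds alone.

Compound 1 `Cc1cc(C(N)=O)nn1Cc1cc(Cl)ccc1OCc1ccccc1` gives 3.7 in a physicochemical assay for lipophilicity, at pH 7.4; on this read-out lower numbers stand for lower lipophilicity and higher numbers for higher lipophilicity. Compound 2 `Cc1cc(C(=O)Nc2ccccn2)nn1Cc1cc(Cl)ccc1OCc1ccccc1` reaches only the upper limit of that assay, > 3.7, which is a limit and not a number. Compound 3 `Cc1cc(C(=O)NCc2ccccc2)nn1Cc1cc(Cl)ccc1OCc1ccccc1` likewise sits at the limit, > 3.7, so its true position is not known. The steps of a number no lower from compound 1 to compound 2 (the limit leaves the size open) and a number no lower from compound 1 to compound 3 (the limit leaves the size open) therefore show only that nothing fell, and a step that the two limits leave unreadable from compound 2 to compound 3 cannot be read at all because of the limit of > 3.7 in this assay, at which 2 of the 3 values shown sit. Compound 4 `Cc1cc(C(=O)NCc2ccccn2)nn1Cc1cc(Cl)ccc1OCc1ccccc1` differs from compound 3 by pyridin-2-yl in place of phenyl on a saturated chain carbon bound to an amide-type nitrogen. Among the measured compounds shown here, none of the measured steps gives a readable size for such an exchange, so the direction and size must be estimated from the structures alone rather than from the numbers. The step that the limit leaves unreadable from compound 3 to compound 4 is estimated to point downward. Compound 4 is expected to come out near the limit, at 4, within a range from 3.3 to 4.7, with a fair chance that this assay again reports only a limit.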

Compound 4, distribution coefficient: > 3.7
Compound 4 gave a limit, no number; the forecaster's own chance of this, stated with the estimate: 65%; the middle value is on the limit's open side.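

In this assay compound 4 gives only a limit, not a number. With pyridin-2-yl in place of phenyl the value stays off the readable scale, so any fall this exchange brings remains hidden, and a number no lower from compound 1 to compound 4 (the limit leaves the size open) is all that can be said against the plain amide. The steps from compound 3 to compound 4 and from compound 2 to compound 4 cannot be read, because both ends of each step sit at the same limit: the limit of > 3.7 in this assay, at which 3 of the 4 values shown sit.

From the compounds shown here alone, how far compound 2, compound 3 and compound 4 lie past that limit stays open, and so does the true size of the benzyl to (pyridin-2-yl)methyl change. Also open, going by these compounds, is whether an amine or a carboxylic acid carried on the amide-type nitrogen would bring the value back to a readable number.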